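The source may report more compounds than this note shows. Statements on the series, on what has been measured and on what is new or still open speak of the compounds shown alone.

Three compounds that share one core have been tested so far:

Compound 1 `COc1ccc(-n2cc(COc3ccc(C[C@H]4C(=O)OC[C@@H]4Cc4ccc(OC)c(OC)c4)cc3OC)nn2)cc1` gives >= 600000 nM in an ADME assay on HeLa cells (Homo sapiens) for cytotoxicity, read by MTT assay (on this read-out higher numbers stand for weaker inhibition and lower numbers for stronger inhibition), a value that is a limit of the assay rather than a number.
Compound 2 `CCN1CCN(C(=O)CCC(=O)Oc2ccc(C[C@H]3C(=O)OC[C@@H]3Cc3ccc(OC)c(OC)c3)cc2OC)CC1` gives 190000 nM in this assay.
Compound 3 `COC(=O)[C@H](CCSC)NC(=O)CCC(=O)Oc1ccc(C[C@H]2C(=O)OC[C@@H]2Cc2ccc(OC)c(OC)c2)cc1OC` gives 199000 nM in this assay.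

Compound 1 therefore stands at the edge of what this assay can report; among the three values, one sits at that limit (the limit of >= 600000 nM in this assay, at which 1 of the 3 values shown sits). Within the data shown here, the only measured step, a 1.0-fold higher number from compound 2 to compound 3 (0.02 log units; within the scatter), concerns an exchange on a carbonyl carbon in a different part of the core and stays within the scatter, so it says nothing directly about the change now considered.

The unmeasured compound 4 `COc1ccc(C[C@H]2COC(=O)[C@@H]2Cc2ccc(OCc3cn(-c4ccc(F)cc4)nn3)c(OC)c2)cc1OC` differs from compound 1 by fluoro in place of methoxy on an aromatic carbon. Among the measured compounds shown here, no measured step bears on this exchange. With compound 1 already at a limit and no step of any size shown for a change of this kind, the expectation is for no step beyond the scatter, namely a number no higher from compound 1 to compound 4 (the limit leaves the size open). Compound 4 is therefore estimated at 600000 nM, within a range from 300000 nM to 1200000 nM, and most likely the assay will again report only a limit.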

Compound 4, half-maximal inhibitory concentration: >= 600000 nM
Compound 4: only a limit was reported; the forecaster's own chance of this, stated with the estimate: 70%; the middle value sits exactly at the limit.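

Among these compounds, compound 1 and compound 4 are both reported only as a limit, so no step between them can be read: the limit of >= 600000 nM in this assay, at which 2 of the 4 values shown sit. The compounds shown leave open whether 4-fluorophenyl in place of 4-methoxyphenyl shifts the true value in this assay at all.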